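Replacing a trimethylpyrazole with a pyridine: expected solubility

The source may hold more compounds than are shown below. What is called first, only, known or untested is meant among the compounds shown, and "the series" means these compounds.

Compound 3 `Cc1ccc(-c2c(C)nn(C)c2C)cc1NC(=O)c1ccc(OCc2ccccn2)cc1` is examined in a physicochemical assay for solubility, at pH 7.4; a higher number here means a more soluble compound, a lower number a less soluble compound. Among the two compounds that have a number here, compound 3 stands lowest with 5000 nM. Going by the values given here, its nearest neighbour is compound 2 `Cc1ccc(-c2c[nH]cn2)cc1NC(=O)c1ccc(OCc2ccccn2)cc1`, which gives 90000 nM; the one change between the two brought an 18-fold lower number from compound 2 to compound 3 (1.26 log units; beyond the scatter), a large shift, when 1,3,5-trimethyl-1H-pyrazol-4-yl took the place of 1H-imidazol-4-yl on an aromatic carbon. Compound 1 `Cc1ccc(NC(=O)c2cccc(N(C)C)c2)cc1NC(=O)c1ccc(OC(C)C)cc1` gives < 1000 nM in this assay, which is a limit of the assay and not a number; it sits at the limit of < 1000 nM in this assay, at which 1 of the 3 values shown sits.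

Compound 4 `Cc1ccc(-c2cccnc2)cc1NC(=O)c1ccc(OCc2ccccn2)cc1` differs from compound 3 in one place: pyridin-3-yl in place of 1,3,5-trimethyl-1H-pyrazol-4-yl on an aromatic carbon. Among the compounds with values here, no measured step swaps these two particular groups, so the only guide is the single large step already seen on the same ring position, in which the group now leaving was the one that entered. That step ran downward; the present change reverses part of it, and a moderate rise in this assay is therefore expected for compound 4, namely a 2.4-fold higher number from compound 3 to compound 4 (0.38 log units; beyond the scatter). The expected value for compound 4 is 12000 nM, with a likely range from 3000 nM to 45000 nM.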

Compound 4, solubility: < 1000 nM
Compound 4: only a limit was reported (the forecaster's own chance of this, stated with the estimate: 8%); middle value at least 12-fold (1.07 log units) from the limit.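

Placing pyridin-3-yl on this aromatic carbon gave an at least 5.0-fold lower number from compound 3 to compound 4 (0.69 log units; beyond the scatter) in this assay, so a six-membered aromatic ring here does not bring back the number seen with the 1H-imidazol-4-yl group. The distance from that group is wider still, at an at least 90-fold lower number from compound 2 to compound 4 (1.95 log units; beyond the scatter), and among the three groups compared at this position, 1H-imidazol-4-yl now stands apart. Compound 4 carries a limit of the assay and not a number, so both steps are minimum sizes: the limit of < 1000 nM in this assay, at which 2 of the 4 values shown sit.

The compounds shown leave open which feature of the 1H-imidazol-4-yl group sets it apart, as the three groups differ in more than one way at once. An unsubstituted pyrazole, an amine or a carboxylic acid on this same aromatic carbon could show whether other groups reach the number of compound 2.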